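The compounds below may be only part of what the source reports. "The series", "measured", "known", "first", "only" and "open" are said of these compounds alone.

Compound 3 `N#C/N=C1\N(CCCCCOc2ccc(Cl)cc2)C(=O)C(c2ccccc2)N1c1ccncc1` gives 3590 nM in a functional assay on HA22T cells for cytotoxicity against HA22T cell line (Homo sapiens) (on this read-out higher numbers stand for weaker inhibition and lower numbers for stronger inhibition), the second highest of the three numbers seen; compound 2 `CCC1C(=O)N(CCCCCCCOc2ccc(Cl)cc2)/C(=N\C#N)N1c1ccncc1` with 6050 nM sits within the scatter of it, while compound 1 `CC1C(=O)N(CCCCCCCOc2ccc(Cl)cc2)/C(=N\C#N)N1c1ccncc1` with 688 nM stands beyond the scatter, lower. Compound 4 `N#C/N=C1\N(CCCCCCCOc2ccc(Cl)cc2)C(=O)C(c2ccccc2)N1c1ccncc1` differs from compound 3 by 2-(4-chlorophenoxy)ethyl in place of 4-chlorophenoxy on a saturated chain carbon, five bonds along the chain from an amide-type nitrogen in a ring. Going by the values given here, the only measured step, an 8.8-fold higher number from compound 1 to compound 2 (0.94 log units; beyond the scatter), concerns a methyl in place of hydrogen on a saturated ring carbon and does not touch the chain; no measured pair varies the chain alone. Compounds 1 and 2 carry the longer chain of compound 4, yet one lies below compound 3 and one level with it, so no direction follows. The step of a 1.4-fold lower number from compound 3 to compound 4 (0.16 log units; within the scatter) is expected to stay within the scatter. Compound 4 is estimated at 2500 nM, within 700 nM to 9000 nM.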

Compound 4, half-maximal inhibitory concentration: 831 nM
For compound 4 the middle estimate is 3.0-fold (0.48 log units) above the measured one; measured number inside the range.
By their numbers in this assay, from the lowest: compounds 1 and 4 (each within the scatter of the next); then compounds 3 and 2 (each within the scatter of the next).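

In this assay the chain position now has a reading of its own: 2-(4-chlorophenoxy)ethyl in place of 4-chlorophenoxy, with phenyl held on the ring carbon, moves the number beyond the scatter (a 4.3-fold lower number from compound 3 to compound 4 (0.64 log units; beyond the scatter)). With the longer chain held, phenyl differs from ethyl (a 7.3-fold lower number from compound 2 to compound 4 (0.86 log units; beyond the scatter)) but not from methyl (a 1.2-fold higher number from compound 1 to compound 4 (0.08 log units; within the scatter)). Nothing available gives a cause for these steps.

From the compounds shown here alone, whether the chain step repeats with methyl or ethyl on the ring carbon stays open. So does the outcome of a still longer chain, or of an amine in place of 4-chlorophenoxy.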